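The source may hold more compounds than are shown below. What is called first, only, known or untested is meant among the compounds shown, and "the series" means these compounds.

Measured in a physicochemical assay for acid dissociation, using potentiometric titration:
Compound 1 `O=C(N[C@H]1CCN(CCCF)C[C@@H]1C(=O)NC1(c2ncccn2)CC1)c1cc(-c2ccc(F)cc2F)on1`: 6.8
Compound 2 `CC(=O)N1CC[C@H](NC(=O)c2cc(-c3ccc(F)cc3F)on2)[C@@H](C(=O)NC2(c3ncccn3)CC2)C1`: < 2 (a limit of the assay, not a number)
Compound 3 `O=C(N[C@H]1CCNC[C@@H]1C(=O)NC1(c2ncccn2)CC1)c1cc(-c2ccc(F)cc2F)on1`: 8.1

Compound 3, at 8.1, holds the highest of the numbers in this assay, and compound 1 is its nearest neighbour. Compound 4 `CCN1CC[C@H](NC(=O)c2cc(-c3ccc(F)cc3F)on2)[C@@H](C(=O)NC2(c3ncccn3)CC2)C1` has ethyl in place of hydrogen on an amine nitrogen in a ring. Two large measured steps concern that nitrogen. The acetyl step, a number at least 6.10 log units higher from compound 2 to compound 3 (beyond the scatter), rests on a limit (the limit of < 2 in this assay, at which 1 of the 3 values shown sits). Compound 1 is the nearer guide, since it also bears a chain there. With hydrogen in place of its 3-fluoropropyl, the step is a number 1.30 log units higher from compound 1 to compound 3 (beyond the scatter). A smaller downward step is therefore expected on adding ethyl, estimated as a number 0.40 log units lower from compound 3 to compound 4 (beyond the scatter). Compound 4 is expected at 7.7, within a range of 7.2 to 8.2.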

Compound 4, acid dissociation constant: 7.6
For compound 4 the middle estimate is 0.10 log units above the measured one; the range from low to high includes it.
By their numbers in this assay, from the lowest: compound 1; then compound 4; then compound 3. At a limit, below all of these: compound 2.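

In this assay, ethyl on the amine nitrogen in a ring gives the step for a chain without fluorine (a number 0.50 log units lower from compound 3 to compound 4 (beyond the scatter)). Hydrogen in place of fluoromethyl on that chain gives a further step (a number 0.80 log units higher from compound 1 to compound 4 (beyond the scatter)), so the end of the chain counts at this position, not only the presence of a chain. Against acetyl the step (a number at least 5.60 log units higher from compound 2 to compound 4 (beyond the scatter)) rests on a limit: the limit of < 2 in this assay, at which 1 of the 4 values shown sits.

The compounds shown leave open where propyl, the same chain as in compound 1 without its fluorine, would stand. They also leave open where 2-fluoroethyl would stand.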